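Chloro to (trifluoromethyl)sulfanyl on a shared urea core

The source may report more compounds than this note shows. Statements on the series, on what has been measured and on what is new or still open speak of the compounds shown alone.

Three compounds share one urea core and differ only in the group on one aromatic carbon. Compound 1 `Cc1cc(NC(=O)Nc2ccc(C(=O)O)cc2)c2ccccc2n1` carries carboxy there. In an ADME assay on BJ cells (Homo sapiens) for cytotoxicity, with a stated time of 72 h (on this read-out higher numbers stand for an effect only at larger amounts of compound and lower numbers for an effect already at smaller amounts), compound 1 gives > 25000 nM, which is a limit of the assay and not a number. Compound 2 `Cc1cc(NC(=O)Nc2ccc(F)cc2)c2ccccc2n1` carries fluoro in that place. In this assay compound 2 gives > 25000 nM, again a limit. Compound 3 `Cc1cc(NC(=O)Nc2ccc(Cl)cc2)c2ccccc2n1` carries chloro. In this assay compound 3 gives > 25000 nM, also a limit. The steps a step that the two limits leave unreadable from compound 1 to compound 2, a step that the two limits leave unreadable from compound 1 to compound 3 and a step that the two limits leave unreadable from compound 2 to compound 3 cannot be sized, since all three values sit at the limit of > 25000 nM in this assay, at which 3 of the 3 values shown sit.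

Compound 4 `Cc1cc(NC(=O)Nc2ccc(SC(F)(F)F)cc2)c2ccccc2n1` differs from compound 3 by (trifluoromethyl)sulfanyl in place of chloro on an aromatic carbon. None of the measured steps has a readable size, so the data give no direction for this change and no reason to expect a step beyond the scatter. Within the data shown here, the only anchor is that compound 3 gives > 25000 nM, and every variation of this position so far has left the read-out at the same limit. Compound 4 is therefore expected to give 30000 nM, with a range from 10000 nM to 100000 nM. This estimate corresponds to an expected step that the limit leaves unreadable from compound 3 to compound 4, most probably reported as a limit once more.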

Compound 4, half-maximal effective concentration: > 25000 nM
Compound 4: a limit, no number (the forecaster's own chance of this, stated with the estimate: 85%); the middle value is on the limit's open side.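

Compound 4 gives a limit and not a number, as do compound 1, compound 2 and compound 3, so no step among these four compounds can be read in this assay: the limit of > 25000 nM in this assay, at which 4 of the 4 values shown sit.

The compounds shown leave open whether changing the group on this aromatic carbon has any effect on this read-out, and how large such an effect would be.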